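This account rests on a few compounds, and the source may have more. Where it says the series, first, only, none or still open, it means among the compounds named here.

In an ADME assay on THP-1 cells (Homo sapiens) for cytotoxicity, read by resazurin assay, with a stated time of 72 h (a higher number here means that more compound is tolerated, a lower number that less compound is tolerated), compound 1 `CC(C)(C)c1ccc(C(=O)/C=C/c2ccc([N+](=O)[O-])o2)cc1` stands only at a limit: compound 1 gives > 50000 nM, which is a limit of the assay rather than a number. Compound 3 `CC(C)(C)c1ccc(C(=O)/C=C/c2ccco2)cc1` likewise gives > 50000 nM, again a limit. The step that the two limits leave unreadable from compound 1 to compound 3 therefore cannot be sized, because both of its values sit at the limit of > 50000 nM in this assay, at which 2 of the 3 values shown sit. Among the compounds with values here, the one read number belongs to compound 2 `Cc1ccccc1C(=O)/C=C/c1ccc([N+](=O)[O-])o1`, which gives 27900 nM. Compound 4 `O=C(/C=C/c1ccc([N+](=O)[O-])o1)c1ccc(-n2ccnc2)cc1` differs from compound 1 by 1H-imidazol-1-yl in place of tert-butyl on an aromatic carbon. Within the data shown here, no measured step covers this change, so the step of a number no higher from compound 1 to compound 4 (the limit leaves the size open) is expected to remain small, and another limit seems likely. For compound 4 the estimate is 50000 nM, within 20000 nM to 120000 nM.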

Compound 4, half-maximal cytotoxic concentration: 22200 nM
Compound 4: middle estimate off by 2.3-fold (0.35 log units), on the high side; the measured number falls inside the stated range.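

Within the data shown here, the one earlier step in this assay could not be read, but this one can: 1H-imidazol-1-yl in place of tert-butyl gives an at least 2.2-fold lower number from compound 1 to compound 4 (0.35 log units; beyond the scatter). The group on this aromatic carbon, para to a large group, can therefore shift the number beyond the scatter. Only a minimum size is known, as the value for compound 1 is a limit: the limit of > 50000 nM in this assay, at which 2 of the 4 values shown sit.

From the compounds shown here alone, whether 1H-imidazol-1-yl is special here, or an amine or a carboxylic acid at this place would lower the number too, remains open. So does the size of this change on a core without the nitro group.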